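Naphthalen-1-yl on the saturated ring carbon

The source may report more compounds than this note shows. Statements on the series, on what has been measured and on what is new or still open speak of the compounds shown alone.

In a functional assay on WM 266-4 cells (Homo sapiens) for antiproliferative activity, read by MTT assay, with a stated time of 24 h (a lower number here means a stronger inhibitor of growth, a higher number a weaker inhibitor of growth), compound 1 (`COc1ccc(C2CC(c3ccc4c(c3)OCCO4)=NN2c2ccccc2)cc1OC`) gives 2160 nM and compound 2 (`c1ccc(N2N=C(c3ccc4c(c3)OCCO4)CC2c2ccc3ccccc3c2)cc1`) gives 13900 nM. Compound 3 (`Cc1ccc(C2CC(c3ccc4c(c3)OCCO4)=NN2c2ccccc2)cc1`) gives 2530 nM, within the scatter of compound 1 and well below compound 2.

Compound 4 (`c1ccc(N2N=C(c3ccc4c(c3)OCCO4)CC2c2cccc3ccccc23)cc1`) carries naphthalen-1-yl in place of 4-methylphenyl on a saturated ring carbon. Among the compounds with values here, the closest precedent is the isomeric naphthalen-2-yl in compound 2, read in reverse from a 5.5-fold lower number from compound 2 to compound 3 (0.74 log units; beyond the scatter). The step of a 6.4-fold higher number from compound 1 to compound 2 (0.81 log units; beyond the scatter) points the same way, whereas a 1.2-fold higher number from compound 1 to compound 3 (0.07 log units; within the scatter) is small. No naphthalen-1-yl value exists yet, so a modest rise in this assay is expected: a 4.0-fold higher number from compound 3 to compound 4 (0.60 log units; beyond the scatter). For compound 4 the estimated value is 10000 nM, with an expected range of 4000 nM to 25000 nM.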

Compound 4, concentration for 50% growth inhibition: > 100000 nM
Compound 4: no number, only a limit; the forecaster's own chance of this, stated with the estimate: 5%; middle value at least 10-fold (1.00 log units) from the limit.
By their numbers in this assay, from the lowest: compounds 1 and 3 (each within the scatter of the next); then compound 2. At a limit, above all of these: compound 4.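

In this assay compound 4 is reported only as a limit, not as a number: the limit of > 100000 nM in this assay, at which 1 of the 4 values shown sits. Within the data shown here, on the saturated ring carbon, the attachment point of the naphthalene separates two isomers, with an at least 7.1-fold higher number from compound 2 to compound 4 (0.85 log units; beyond the scatter), which the earlier compounds could not show. The steps from the two substituted phenyl compounds are large: an at least 39-fold higher number from compound 3 to compound 4 (1.59 log units; beyond the scatter) and an at least 46-fold higher number from compound 1 to compound 4 (1.66 log units; beyond the scatter).

Going by these compounds, how far compound 4 lies beyond its limit stays unknown. On these data alone, whether a phenyl group carrying an amine or a carboxylic acid at this carbon would keep the values of compound 1 and compound 3 remains open.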